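This account rests on a few compounds, and the source may have more. Where it says the series, first, only, none or still open, it means among the compounds named here.

Measured compounds: compound 1 `O=[N+]([O-])c1ccc(NC(=S)NCCNS(=O)(=O)c2ccc(-c3ccccc3O[C@H]3CC[C@@H](O)CC3)s2)cc1` gives 20000 nM in an ADME assay on HEK-293T cells (Homo sapiens) for cytotoxicity, read by CCK-8 assay, with a stated time of 48 h; a higher number here means a weaker inhibitor, a lower number a stronger inhibitor. Compound 2 `O=C(NCCNS(=O)(=O)c1ccc(-c2ccccc2OCc2cccc(O)c2)s1)Nc1cc(C(F)(F)F)cc(C(F)(F)F)c1` reaches only the limit of this assay, > 20000 nM. Compound 3 `O=[N+]([O-])c1ccc(NC(=S)NCCNS(=O)(=O)c2ccc(-c3ccccc3OCc3cccc(O)c3)s2)cc1` likewise reaches only the limit, > 20000 nM.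

Compound 4 `O=C(NCCNS(=O)(=O)c1ccc(-c2ccccc2O[C@H]2CC[C@@H](O)CC2)s1)Nc1cc(C(F)(F)F)cc(C(F)(F)F)c1` is not yet measured. It differs from compound 2 by 4-hydroxycyclohexyl in place of 3-hydroxybenzyl on an oxygen on an aromatic ring. The same change separates compound 3 from compound 1, (4-hydroxycyclohexyl in place of 3-hydroxybenzyl on an oxygen on an aromatic ring), and there it gave a number no higher from compound 3 to compound 1 (the limit leaves the size open). The difference between the cores of compound 2 and compound 3 is not broken down here. Since the size of the measured step cannot be read, the expectation rests on the limit of > 20000 nM in this assay, at which 2 of the 3 values shown sit: all three values sit at or near that limit, so the change from compound 2 to compound 4 is expected to give a step of about a number no higher from compound 2 to compound 4 (the limit leaves the size open). Compound 4 is therefore expected to give around 20000 nM in this assay, most likely reported only as a limit, with a range of 10000 nM to 40000 nM.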

Compound 4, half-maximal inhibitory concentration: 14100 nM
Compound 4: the middle estimate sits 1.4-fold (0.15 log units) above what was measured; the measured number falls inside the stated range.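

In this assay, putting 4-hydroxycyclohexyl in place of 3-hydroxybenzyl on the oxygen gives an at least 1.4-fold lower number from compound 2 to compound 4 (0.15 log units; that floor lies within the scatter). Set beside the same change on the other core, the result reads: the same change on two cores in this assay, a number no higher (the limit leaves the size open) from compound 3 to compound 1 and an at least 1.4-fold lower number (0.15 log units; that floor lies within the scatter) from compound 2 to compound 4; the limit leaves it open whether they differ. Neither core shows a higher number after the change, but neither step has a size that can be read, so no size can be carried from one core to the other.

The compounds shown leave open whether a step beyond the usual scatter appears on either core. They also leave open what an amine or a carboxylic acid would do in place of the hydroxyl on the cyclohexyl ring.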